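The source may hold more compounds than are shown below. What is called first, only, known or untested is meant among the compounds shown, and "the series" means these compounds.

Measured compounds:
compound 1 `O=c1c(S(=O)(=O)c2ccc(F)cc2F)cc2cnc(Nc3ccc4[nH]ccc4c3)nc2n1CC1CC1`: 1000 nM
compound 2 `O=c1c(S(=O)(=O)c2ccc(F)cc2F)cc2cnc(Nc3ccc4[nH]ccc4c3)nc2n1CC1CCCC1`: 10000 nM
compound 3 `O=c1c(S(=O)(=O)c2ccc(F)cc2F)cc2cnc(Nc3ccc4[nH]ccc4c3)nc2n1C1CCCCC1`: 10000 nM

In a functional assay on DU-145 cells (Homo sapiens) for inhibition, read by trypan blue exclusion, with a stated time of 72 h (on this read-out higher numbers stand for weaker inhibition and lower numbers for stronger inhibition), compound 3 gives 10000 nM, level with compound 2 at the digits printed; together these are the highest numbers of the three. The nearest neighbour is compound 2, with no change at the digits printed from compound 2 to compound 3 (within the scatter). The furthest is compound 1, with a 10-fold higher number from compound 1 to compound 3 (1.00 log units; beyond the scatter).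

Compound 4 `COC(=O)Cn1c(=O)c(S(=O)(=O)c2ccc(F)cc2F)cc2cnc(Nc3ccc4[nH]ccc4c3)nc21` has not yet been measured. Its change from compound 3: (methoxycarbonyl)methyl in place of cyclohexyl on an aromatic nitrogen. The measured steps that bear on this all concern the group on the aromatic nitrogen. Replacing the smallest group gave a 10-fold higher number from compound 1 to compound 2 (1.00 log units; beyond the scatter) and a 10-fold higher number from compound 1 to compound 3 (1.00 log units; beyond the scatter); between the two larger groups there was no change at the digits printed from compound 2 to compound 3 (within the scatter). Going by the values given here, the entering (methoxycarbonyl)methyl has no ring and is smaller than cyclohexyl, so a move back toward the level of compound 1 is expected rather than a further rise, though no measured step involves a chain carrying two hydrogen-bond acceptors, so the estimate is loose. For compound 4 the step expected is a 3.3-fold lower number from compound 3 to compound 4 (0.52 log units; beyond the scatter). Compound 4 is therefore estimated at 3000 nM, within 800 nM to 12000 nM.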

Compound 4, half-maximal inhibitory concentration: 10000 nM
Beside the measured number, compound 4's estimate is 3.3-fold (0.52 log units) below it, and the stated range covers the measured number.
By their numbers in this assay, from the lowest: compound 1; then compounds 2, 3 and 4 (each within the scatter of the next).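

In this assay a ring on the aromatic nitrogen is not needed to reach the high level: (methoxycarbonyl)methyl, with no ring and with hydrogen-bond acceptors, shows no change at the digits printed from compound 3 to compound 4 (within the scatter) against cyclohexyl and no change at the digits printed from compound 2 to compound 4 (within the scatter) against cyclopentylmethyl. Cyclopropylmethyl remains the only group here that stands apart, with a 10-fold higher number from compound 1 to compound 4 (1.00 log units; beyond the scatter) on this change, so the three larger-numbered compounds now span ring and open-chain groups alike. Nothing measured here gives a reason for this shared level.

Open, as far as these compounds go, is whether a carboxylic acid in place of the methyl ester, an amine, or a longer chain on this nitrogen would keep that level or return toward compound 1. Also open, from the compounds shown here alone, is whether a small open-chain group such as ethyl would match cyclopropylmethyl.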